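The source may hold more compounds than are shown below. What is called first, only, known or untested is meant among the compounds shown, and "the series" means these compounds.

Measured in an ADME assay on HeLa cells (Homo sapiens) for cytotoxicity, read by crystal violet staining, with a stated time of 72 h; a higher number here means that more compound is tolerated, a lower number that less compound is tolerated:
Compound 1 `CCOC(=O)c1cc(CCCOc2ccc(-c3noc(C(F)(F)F)n3)cc2)on1`: > 100000 nM
Compound 2 `CCOC(=O)c1cc(CCCOc2ccc(-c3noc(C(F)(F)F)n3)cc2OC)on1`: > 100000 nM
Compound 3 `Cc1cc(-c2noc(C(F)(F)F)n2)cc(C)c1OCCCc1cc(-c2ccccc2)no1`: > 100000 nM

Each of these entries is a limit of the assay and not a number. No order can be read among the three compounds, and compound 3 has no rank of its own: the limit of > 100000 nM in this assay, at which 3 of the 3 values shown sit.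

Compound 4 `Cc1cc(-c2noc(C(F)(F)F)n2)cc(C)c1OCCCc1cc(C(=O)N(C)C)no1` carries dimethylcarbamoyl in place of phenyl on an aromatic carbon of compound 3: dimethylcarbamoyl in place of phenyl on an aromatic carbon.

Among the compounds with values here, only one measured step exists, a step that the two limits leave unreadable from compound 1 to compound 2. It concerns methoxy in place of hydrogen on an aromatic carbon, which is a different change, and it offers no size to carry over. The expectation therefore rests on compound 3, whose > 100000 nM is a limit. No step beyond the scatter is expected in this assay, in either direction, and compound 4 may well report only a limit too.

The estimate amounts to an expected a number no higher from compound 3 to compound 4 (the limit leaves the size open).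

In this assay the estimate for compound 4 is 100000 nM, with an expected range from 50000 nM to 200000 nM.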

Compound 4, half-maximal cytotoxic concentration: 13200 nM
Estimate against measurement, compound 4: 7.6-fold (0.88 log units) above, outside the stated range (below it).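

In this assay, the place next to the ring nitrogen of the five-membered aromatic ring proves responsive to change: dimethylcarbamoyl in place of phenyl gives an at least 7.5-fold lower number from compound 3 to compound 4 (0.87 log units; beyond the scatter). Within the data shown here, the earlier compounds could show nothing of this kind, since the only step among them, methoxy in place of hydrogen on an aromatic carbon, cannot be read between its two limits. Compound 4 is the only compound shown that gives a number and not a limit: the limit of > 100000 nM in this assay, at which 3 of the 4 values shown sit.

The compounds shown leave open whether the step follows from the loss of phenyl or from the entry of dimethylcarbamoyl, and how a carboxylic acid, an amine or a primary amide would read at this place. They also leave open whether the same change would give a similar step on the core of compound 1.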